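This account rests on a few compounds, and the source may have more. Where it says the series, first, only, none or still open, it means among the compounds named here.

Series notes, a functional assay on B16-F0 cells (Mus musculus) for inhibition, read by CCK-8 assay, with a stated time of 48 h; on this read-out lower numbers stand for stronger inhibition and higher numbers for weaker inhibition:
compound 1 `COc1ccc(-c2cc3nccc(-c4cc(OC)c(OC)c(OC)c4)n3n2)cc1N` gives 88 nM
compound 2 `COc1cc(-c2ccnc3cc(-c4ccccc4)nn23)cc(OC)c1OC` gives 4730 nM
compound 3 `COc1cc(-c2ccnc3cc(-c4ccc(N(C)C)cc4)nn23)cc(OC)c1OC` gives 702 nM

Compound 1 gives the lowest number of the three; compound 3 is nearest and compound 2 furthest, both steps beyond the scatter. Compound 4 `COc1cc(-c2ccnc3cc(-c4ccc(C(F)(F)F)cc4)nn23)cc(OC)c1OC` is the next case: 4-(trifluoromethyl)phenyl in place of 3-amino-4-methoxyphenyl on an aromatic carbon. Among the compounds with values here, the steps that bear on it are the two that also replace the 3-amino-4-methoxyphenyl of compound 1: a 54-fold higher number from compound 1 to compound 2 (1.73 log units; beyond the scatter) and an 8.0-fold higher number from compound 1 to compound 3 (0.90 log units; beyond the scatter). Both move upward. Within the data shown here, the step of a 6.7-fold lower number from compound 2 to compound 3 (0.83 log units; beyond the scatter) shows that a group on the entering phenyl can pull part of that loss back, but no measured compound carries a trifluoromethyl there. The expected step for compound 4 is therefore upward and large: a 57-fold higher number from compound 1 to compound 4 (1.75 log units; beyond the scatter). Compound 4 is estimated at 5000 nM, range 1500 nM to 15000 nM.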

Compound 4, half-maximal inhibitory concentration: 1770 nM
Compound 4: middle estimate off by 2.8-fold (0.45 log units), on the high side; the range from low to high includes it.
By their numbers in this assay, from the lowest: compound 1; then compound 3; then compound 4; then compound 2.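

In this assay, a trifluoromethyl on the entering phenyl does not restore the level of compound 1 (a 20-fold higher number from compound 1 to compound 4 (1.30 log units; beyond the scatter)), yet it does improve on the unsubstituted phenyl (a 2.7-fold lower number from compound 2 to compound 4 (0.43 log units; beyond the scatter)). The recovery seen at this aromatic carbon is therefore not unique to dimethylamino, although dimethylamino gives the lower number (a 2.5-fold higher number from compound 3 to compound 4 (0.40 log units; beyond the scatter)). No measurement at hand accounts for this order of groups.

Still open, as far as these compounds go, is whether the amine or the methoxy of compound 1 accounts for its lower number. Within the data shown here, a phenyl carrying only one of these two groups would separate them.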